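A few compounds are considered here, and "the series" means these few. Any claim that something is new, unique, unknown or untested is made for them only; others in the source may bear on it.

Measured compounds:
- compound 1, `Cn1c(=O)c(=O)n(C2CCCC2)c2nc(N/N=C/c3ccccc3)ncc21`: > 100000 nM
- compound 2, `Cn1c(=O)c(=O)n(C2CCCC2)c2nc(N/N=C/c3ccco3)ncc21`: > 100000 nM
- compound 3, `Cn1c(=O)c(=O)n(C2CCCC2)c2nc(N/N=C/c3cccs3)ncc21`: > 100000 nM

All three share one core and differ only in the ring that hangs on a carbon with a double bond to nitrogen. In a functional assay on A549 cells (Homo sapiens) for antiproliferative activity, read by MTT assay (on this read-out higher numbers stand for weaker inhibition and lower numbers for stronger inhibition), compound 3 gives > 100000 nM, which is a limit of the assay and not a measured number. The same holds for compound 1, whose value in this assay is > 100000 nM, a limit. Compound 2 likewise reaches only a limit, > 100000 nM. Because of the limit of > 100000 nM in this assay, at which 3 of the 3 values shown sit, none of the three steps can be sized: the step that the two limits leave unreadable from compound 1 to compound 2, the step that the two limits leave unreadable from compound 1 to compound 3 and the step that the two limits leave unreadable from compound 2 to compound 3 are all hidden by the limit, so nothing is known about how these rings differ in effect.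

Compound 4, `Cn1c(=O)c(=O)n(C2CCCC2)c2nc(N/N=C/c3cccc([N+](=O)[O-])c3)ncc21`, changes compound 3 in one place: 3-nitrophenyl in place of thiophen-2-yl on a carbon with a double bond to nitrogen. Within the data shown here, no measured step bears on a nitrophenyl ring here, and the three known steps offer no readable size. With every measured neighbour at the limit, compound 4 is expected to sit there too, so the step of a number no higher from compound 3 to compound 4 (the limit leaves the size open) is estimated as none that can be seen. Compound 4 is thus expected to give about 100000 nM in this assay, within 30000 nM to 300000 nM.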

Compound 4, half-maximal inhibitory concentration: 12300 nM
Compound 4: middle estimate off by 8.1-fold (0.91 log units), on the high side; the measured number lies below the stated range.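

A single added group at this place can bring the series off its limit: in this assay, nitro in place of hydrogen on an aromatic carbon gives an at least 8.1-fold lower number from compound 1 to compound 4 (0.91 log units; beyond the scatter). Swapping the five-membered rings for 3-nitrophenyl gives an at least 8.1-fold lower number from compound 2 to compound 4 (0.91 log units; beyond the scatter) and an at least 8.1-fold lower number from compound 3 to compound 4 (0.91 log units; beyond the scatter), so compound 4 holds the only true number among the four. These sizes are lower bounds only, and the steps among compound 1, compound 2 and compound 3 still cannot be read, because of the ceiling: the limit of > 100000 nM in this assay, at which 3 of the 4 values shown sit.

Going by these compounds, whether the drop belongs to the nitro group itself or to the whole 3-nitrophenyl ring stays open. Also open, on these data alone, is whether an amine or a carboxylic acid in place of the nitro group on the phenyl ring would lower the number as well.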